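Notes on the step from compound 2 to compound 4

A few compounds are considered here, and "the series" means these few. Any claim that something is new, unique, unknown or untested is made for them only; others in the source may bear on it.

Measured in an ADME assay on HCT-116 cells (Homo sapiens) for cytotoxicity, read by CellTiter-Glo, with a stated time of 72 h (on this read-out higher numbers stand for weaker inhibition and lower numbers for stronger inhibition), as follows
- compound 1 (`Cc1cc(C)c(S(=O)(=O)N2CCC(N3CCC(C)CC3)CC2)c(C)c1`) gives > 5000 nM as a limit
- compound 2 (`Cc1cc(C)c(S(=O)(=O)N2CCC(N3CCC(CCO)CC3)CC2)c(C)c1`) gives > 5000 nM as a limit
- compound 3 (`Cc1cc(C)c(S(=O)(=O)N2CCC(N3CCCCCC3)CC2)c(C)c1`) gives > 5000 nM as a limit

All three entries are limits of the assay and not numbers, so the series has a single reference point (the limit of > 5000 nM in this assay, at which 3 of the 3 values shown sit) and no measured number to set against it. Compound 2 stands at > 5000 nM as a limit, with no number of its own.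

Compound 4 (`Cc1cc(C)c(S(=O)(=O)N2CCC(N3CCC(Cc4ccc(F)cc4)CC3)CC2)c(C)c1`) differs from compound 2 (4-fluorophenyl in place of hydroxymethyl on a saturated chain carbon bound to a saturated ring carbon) by having 4-fluorophenyl in place of hydroxymethyl on a saturated chain carbon bound to a saturated ring carbon.

Among the compounds with values here, three measured steps bear on this change (a step that the two limits leave unreadable from compound 1 to compound 2 and a step that the two limits leave unreadable from compound 1 to compound 3 and a step that the two limits leave unreadable from compound 2 to compound 3) and none of them has a readable size or direction. In this assay no step beyond the scatter is therefore expected, and the estimated step (a number no higher from compound 2 to compound 4 (the limit leaves the size open)) carries no claim of direction. For compound 4 the expected value is 5000 nM with an estimated range from 2000 nM to 10000 nM and a report as a limit is the likeliest outcome.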

Compound 4, half-maximal inhibitory concentration: > 5000 nM
Compound 4: a limit, no number (the forecaster's own chance of this, stated with the estimate: 75%); the middle value sits exactly at the limit.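

In this assay compound 4 gives > 5000 nM as a limit and not a number, so no step from compound 1 or compound 2 to compound 4 can be read: the limit of > 5000 nM in this assay, at which 4 of the 4 values shown sit.

The compounds shown leave open whether 4-fluorophenyl in place of hydroxymethyl changes the read-out at all, and how the four compounds would rank.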